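Removing one methyl from the core of a chalcone

A few compounds are considered here, and "the series" means these few. Any claim that something is new, unique, unknown or untested is made for them only; others in the source may bear on it.

Measured so far:
compound 1, `COc1cccc(/C=C/C(=O)c2c(OC)cc(OC)cc2OC)c1`: 20%
compound 2, `COc1cc(OC)c(C(=O)/C=C/c2ccccc2)c(OC)c1`: 19%

For the measured compounds named here, compound 1 has the highest of the two numbers in a functional assay on HCT-116 cells (Homo sapiens), read by fluorescence and BrdU incorporation, with a stated time of 48 h, tested at 10 uM (on this read-out lower numbers stand for a stronger effect and higher numbers for a weaker effect at the one concentration tested), but compound 2 sits right beside it, and the one recorded step, a number 1 percentage points lower from compound 1 to compound 2 (within the scatter), stays within the scatter. The two values therefore say the same thing: at the single concentration tested, both compounds leave only a small share of the read-out, that is, both act strongly.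

The next compound, compound 3, `COc1cccc(/C=C/C(=O)c2c(O)cc(OC)cc2OC)c1`, differs from compound 1 in one place: hydrogen in place of methyl on an oxygen on an aromatic ring. The step from compound 1 to compound 2 touched the other ring and swapped methoxy for hydrogen on an aromatic carbon, so it bears only loosely on a methyl lost from an oxygen on the core ring. Going by the values given here, no measured pair shows the same change. The expectation is therefore cautious: compound 3 is estimated at 30%, with a range from 10% to 60%, which would mean an expected step of a number 10 percentage points higher from compound 1 to compound 3 (within the scatter).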

Compound 3, a percentage reported as activity, at one concentration (the size of the read-out at that concentration, not a potency): 30%
Estimate against measurement, compound 3: no gap at the digits printed; measured number inside the range.
By their numbers in this assay, from the lowest: compounds 2, 1 and 3 (each within the scatter of the next, the first and the last beyond it).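

For the compounds shown here, this is the first look at a change on the core ring itself: in this assay, going from methoxy to hydroxy at this oxygen gives a number 10 percentage points higher from compound 1 to compound 3 (within the scatter). The methyl on this oxygen can therefore be replaced by hydrogen without a shift that stands clear of repeat measurements, and compound 3, which carries a free hydroxy there, reads 30%. Nothing available explains this result or says what the hydroxy does in the cells.

The compounds shown leave open whether this oxygen would tolerate something larger than a methyl, such as a longer chain like ethyl or butyl, or whether an amine in place of the hydroxy would keep the read-out in the same range. They also leave open how compound 1 and compound 3 compare across a range of concentrations, since a reading at one concentration gives the size of the effect there and not a potency.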